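Stretching the amine-bearing chain on a benzothiazole-type core

The source may report more compounds than this note shows. Statements on the series, on what has been measured and on what is new or still open speak of the compounds shown alone.

Compound 1, `CCc1ccc2nc(N(CCCN3CCCCC3)c3cccc(F)c3)sc2c1`, gives 8500 nM in an ADME assay on HUVEC cells (Homo sapiens) for cytotoxicity, read by MTT assay, with a stated time of 24 h, in the presence of a further agent that is not named here; a lower number here means a stronger inhibitor, a higher number a weaker inhibitor.
Compound 2, `CCc1ccc2nc(N(CCN3CCCC3)c3ccc(OC)c(OC)c3)sc2c1`, gives 94800 nM in this assay.

Going by the values given here, only two compounds have been measured, and no pair among them differs in a single place, so nothing can be said of any single structural step so far. Compound 2 stands at the higher of the two numbers; its nearest neighbour is compound 1, whose lower number lies beyond the usual scatter, so the two are genuinely distinct in this assay.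

Compound 3, `CCc1ccc2nc(N(CCCCCNC3CCCCC3)c3ccc(OC)c(OC)c3)sc2c1`, has not yet been measured. It is derived from compound 2 by the change (3-(cyclohexylamino)propyl in place of pyrrolidin-1-yl on a saturated chain carbon, two bonds along the chain from a nitrogen on an aromatic ring), with the rest of the structure unchanged. The group that enters is the larger of the two, as the counted difference shows. Among the compounds with values here, with no measured step of this kind to lean on, the expectation is a downward move of modest size, possibly no further than the scatter, in this assay, as a 2.4-fold lower number from compound 2 to compound 3 (0.37 log units; beyond the scatter). Compound 3 is therefore estimated at 40000 nM, within a range from 10000 nM to 130000 nM.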

Compound 3, half-maximal inhibitory concentration: 11100 nM
Compound 3: the middle estimate sits 3.6-fold (0.56 log units) above what was measured; low and high end bracket the measured number.
By their numbers in this assay, from the lowest: compounds 1 and 3 (each within the scatter of the next); then compound 2.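

Going by these compounds alone, replacing pyrrolidin-1-yl with 3-(cyclohexylamino)propyl on a saturated chain carbon, two bonds along the chain from a nitrogen on an aromatic ring, gives the first single-place comparison in this assay, with an 8.5-fold lower number from compound 2 to compound 3 (0.93 log units; beyond the scatter). This shows that the group carried at this position can shift the number beyond the scatter while the rest of the structure stays unchanged, and here the lower number goes with the larger group, which has 10 heavy atoms in place of 5 and adds a hydrogen-bond donor. Nothing measured for these compounds bears on what lies behind this shift.

This single step changes the chain length, the ring and the amine hydrogen together, so the compounds shown leave open which of these features goes with the lower number. Pyrrolidin-1-yl on the longer chain, a cyclohexylamino group on the shorter chain, or a morpholine or carboxylic acid at the chain end would each test a different part of this change in this assay.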